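The compounds below may be only part of what the source reports. "The series", "measured", "known", "first", "only" and "open" are said of these compounds alone.

In an ADME assay on HeLa cells (Homo sapiens) for cytotoxicity, read by crystal violet staining, with a stated time of 72 h (a higher number here means that more compound is tolerated, a lower number that less compound is tolerated), compound 1 (`CCOC(=O)c1cc(CCCOc2ccc(-c3noc(C(F)(F)F)n3)cc2F)on1`) gives 60200 nM as a measured number. Compound 2 (`CCOC(=O)c1cc(CCCOc2ccc(-c3noc(C(F)(F)F)n3)cc2N)on1`) gives > 100000 nM as a limit of the assay and not a number. Its standing is therefore known only through the limit of > 100000 nM in this assay, at which 1 of the 2 values shown sits, and nothing firmer. The next change leads to compound 3 (`CCOC(=O)c1cc(CCCOc2ccc(-c3noc(C(F)(F)F)n3)cc2NC(C)=O)on1`) and is acetyl in place of hydrogen on a nitrogen on an aromatic ring with acetyl in place of hydrogen on a nitrogen on an aromatic ring, amino to acetamido. Going by the values given here, the one measured step, an at least 1.6-fold higher number from compound 1 to compound 2 (0.22 log units; that floor lies within the scatter) as a floor, is a different change, so it sets no size for this one. In this assay the expected move is an at least 1.1-fold lower number from compound 2 to compound 3 (0.04 log units; that floor lies within the scatter) with no shift beyond the scatter expected in either direction. For compound 3 the estimated value is 90000 nM with an expected range from 40000 nM to 200000 nM and the assay may again report only a limit.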

Compound 3, half-maximal cytotoxic concentration: > 100000 nM
Compound 3: a limit, no number; the forecaster's own chance of this, stated with the estimate: 50%; at least 1.1-fold (0.04 log units) between middle value and limit.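

In this assay compound 3 gives > 100000 nM, which is a limit of the assay and not a number. Acetamido in place of fluoro on this aromatic carbon gives an at least 1.6-fold higher number from compound 1 to compound 3 (0.22 log units; that floor lies within the scatter), so the acetyl on the nitrogen brings no measured value into the series and the floor of this step matches the one seen for amino. The step from compound 2 to compound 3 cannot be read because both compounds sit at the same limit: the limit of > 100000 nM in this assay, at which 2 of the 3 values shown sit.

As far as these compounds go, whether amino and acetamido differ at all in this assay stays open, as does whether either truly differs from fluoro by more than the scatter. From the compounds shown here alone, how a carboxylic acid or a longer acyl chain on this aromatic carbon would read in this assay also remains open.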